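A few compounds are considered here, and "the series" means these few. Any claim that something is new, unique, unknown or untested is made for them only; others in the source may bear on it.

Of the compounds shown here, two sharing one core have been measured so far in a functional assay on K562 cells (Homo sapiens) for inhibition, read by MTT assay, with a stated time of 48 h (a higher number here means a weaker inhibitor, a lower number a stronger inhibitor), and they differ by more than the usual scatter. Compound 1 (`CC(C)(C)C(=O)Nc1ccc(-c2ccc(C(=O)N[C@H]3CN[C@@H](C(=O)Nc4ccc(Cl)c(C(F)(F)F)c4)C3)cc2)cn1`) gives 11600 nM there, and compound 2 (`CS(=O)(=O)Nc1ccc(-c2ccc(C(=O)N[C@H]3CN[C@@H](C(=O)Nc4ccc(Cl)c(C(F)(F)F)c4)C3)cc2)cn1`) gives 45000 nM as the higher of the two numbers, which makes it the weaker inhibitor of the pair. Compound 3 (`O=C(NC1CC1)c1cncc(-c2ccc(C(=O)N[C@H]3CN[C@@H](C(=O)Nc4ccc(Cl)c(C(F)(F)F)c4)C3)cc2)c1`) is still unmeasured. It departs from compound 2 by 5-(cyclopropylcarbamoyl)pyridin-3-yl in place of 6-(methanesulfonamido)pyridin-3-yl on an aromatic carbon, para to a large group (5-(cyclopropylcarbamoyl)pyridin-3-yl in place of 6-(methanesulfonamido)pyridin-3-yl on an aromatic carbon). Read in reverse, the modest step of a 3.9-fold higher number from compound 1 to compound 2 (0.59 log units; beyond the scatter) for methylsulfonyl in place of (tert-butyl)carbonyl on a nitrogen on an aromatic ring points to a lower number for compound 3 once methylsulfonyl is gone, although the entering group is not the one in compound 1. That single step is only a loose guide, so the expected change is a 2.8-fold lower number from compound 2 to compound 3 (0.45 log units; beyond the scatter) and of similar modest size. For compound 3 the estimate is 16000 nM with an expected range from 5000 nM to 45000 nM in this measurement.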

Compound 3, half-maximal inhibitory concentration: 65300 nM
Beside the measured number, compound 3's estimate is 4.1-fold (0.61 log units) below it; measured number outside the range, above it.
By their numbers in this assay, from the lowest: compound 1; then compounds 2 and 3 (each within the scatter of the next).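

In this assay, exchanging 6-(methanesulfonamido)pyridin-3-yl for 5-(cyclopropylcarbamoyl)pyridin-3-yl on this aromatic carbon gives a 1.5-fold higher number from compound 2 to compound 3 (0.16 log units; within the scatter), so these two quite different groups cannot be told apart in this measurement. The loss of methylsulfonyl therefore does not by itself restore the earlier level: the first step, a 3.9-fold higher number from compound 1 to compound 2 (0.59 log units; beyond the scatter), does not carry over to this new group, and the number for compound 3 stays higher than that for compound 1, which gives 11600 nM. Nothing available here explains why compound 2 and compound 3 read alike.

This change alters both the attached group and its numbered place on the pyridine, so the shown compounds cannot separate the effect of one from the other, and the low number of compound 1 could belong to its (tert-butyl)carbonyl group or to the 6-position attachment. Comparing a plain amine at the 6-position of the pyridine, or a carboxylic acid at the 5-position, with the compounds shown would help to separate those two readings.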